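Chloro to methylsulfanyl: working notes on the series

The source may hold more compounds than are shown below. What is called first, only, known or untested is meant among the compounds shown, and "the series" means these compounds.

compound 1 `Cc1nc2c(c(N(C)c3ccc(Cl)cc3)n1)CC(C)C2` | 2300 nM
compound 2 `CN(c1ccc(Cl)cc1)c1ncnc2c1CCC2` | "not determined" (no result reported)

Within the data shown here, in a functional assay on MDA-MB-435 cells (Homo sapiens) for inhibition, read by sulforhodamine B assay, with a stated time of 48 h (a higher number here means a weaker inhibitor, a lower number a stronger inhibitor), compound 1 gives 2300 nM and is the only compound with a number, so it can be ranked against nothing. Compound 3 `CSc1ccc(N(C)c2nc(C)nc3c2CC(C)C3)cc1` carries methylsulfanyl in place of chloro on an aromatic carbon. Among the measured compounds shown here, no measured step bears on this change, so the expectation rests on the structural change alone and stays loose. A moderate gain in strength in this assay is expected, and the estimated step (a 5.8-fold lower number from compound 1 to compound 3 (0.76 log units; beyond the scatter)) may still shrink to nothing beyond the scatter. Compound 3 is estimated at 400 nM (60 nM to 2500 nM).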

Compound 3, half-maximal inhibitory concentration: 15.6 nM
Compound 3: middle estimate off by 26-fold (1.41 log units), on the high side; measured number below the stated range.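

On an aromatic carbon para to a large group, methylsulfanyl in place of chloro gives a 150-fold lower number from compound 1 to compound 3 (2.17 log units; beyond the scatter) in this assay. This place on the ring is therefore sensitive to the group it carries, and a single change there moves the number far beyond the scatter. No measurement at hand accounts for a step of this size.

From the compounds shown here alone, whether methoxy or ethylsulfanyl at the same place would keep this strength stays open. Also open, going by these compounds, is whether the step holds on any core other than that of compound 1.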